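A few compounds are considered here, and "the series" means these few. Any claim that something is new, unique, unknown or untested is made for them only; others in the source may bear on it.

Measured compounds:
- compound 1, `O=C(O)c1cc(-c2cccc(COc3ccc4c(c3)CN(C3CCCC3)C4=O)c2)ccc1O`, 1600 nM in an in vivo ADME assay on the whole organism for pharmacokinetics, with Rattus norvegicus as the target, at a dose of 10 mg/kg by the oral route; on this read-out higher numbers stand for higher exposure at the dose given and lower numbers for lower exposure
- compound 2, `O=C(O)c1cc(-c2cccc(COc3ccc4c(=O)n(C5CC5)sc4c3)c2)ccc1Cl`, 8500 nM in this assay

Among the two numbers in this assay, compound 1 stands lowest; its nearest neighbour is compound 2, whose value lies beyond the usual scatter above it. Compound 3, `COc1ccc(C(=O)O)cc1-c1cccc(COc2ccc3c(c2)CN(C2CCCC2)C3=O)c1`, has not yet been measured in this assay. It keeps the core of compound 1 and changes one group: 5-carboxy-2-methoxyphenyl in place of 3-carboxy-4-hydroxyphenyl on an aromatic carbon. Within the data shown here, no step between measured compounds matches this change, so there is nothing to read a direction from. A step of this kind is expected to stay roughly within the scatter, leaning slightly upward; the expected step is a 1.4-fold higher number from compound 1 to compound 3 (0.14 log units; within the scatter). For compound 3 in this assay the estimate is 2200 nM, in a range from 600 nM to 8000 nM.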

Compound 3, maximal plasma concentration: 4000 nM
For compound 3 the middle estimate is 1.8-fold (0.26 log units) below the measured one; the measured number falls inside the stated range.
By their numbers in this assay, from the lowest: compound 1; then compound 3; then compound 2.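

In this assay, placing 5-carboxy-2-methoxyphenyl where 3-carboxy-4-hydroxyphenyl stood gives a 2.5-fold higher number from compound 1 to compound 3 (0.40 log units; beyond the scatter) and shows that exposure responds to this aromatic position, even with the rest of the molecule unchanged. Among these compounds, the step is modest, but it is the first comparison here between compounds that differ in only one place. The entering group has 1 hydrogen-bond donor where the leaving group has 2, yet nothing measured here explains the rise.

The two groups differ both in the methoxy and hydroxy substituents and in how these are arranged with the carboxylic acid on the ring, and this single step cannot separate those differences. As far as these compounds go, how an ethoxy group or an amine would behave on this ring also remains open.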